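This account rests on a few compounds, and the source may have more. Where it says the series, first, only, none or still open, it means among the compounds named here.

Compound 1 `O=c1cc(-c2ccccc2)oc2cc(OCCCN3CCN(c4ccccc4)CC3)ccc12` and compound 2 `O=c1cc(-c2ccccc2)oc2cc(OCCCCN3CCN(c4ccccc4)CC3)ccc12` share a flavone core bearing a phenylpiperazine side chain; how the two cores differ is not broken down here. In a functional assay for antagonist activity at Adrenergic receptor alpha-1 (Rattus norvegicus) (on this read-out lower numbers stand for tighter binding and higher numbers for weaker binding), compound 1 gives 6.65 nM, and compound 2 gives 4.65 nM. Compound 3 `O=c1cc(-c2ccc(Cl)cc2)oc2cc(OCCCN3CCN(c4ccccc4)CC3)ccc12` carries the change chloro in place of hydrogen on an aromatic carbon relative to compound 1, and in this assay compound 3 gives 8.47 nM, so that the step of a 1.3-fold higher number from compound 1 to compound 3 (0.11 log units; within the scatter) is small. Compound 4 `O=c1cc(-c2ccc(Cl)cc2)oc2cc(OCCCCN3CCN(c4ccccc4)CC3)ccc12` carries the same change, (chloro in place of hydrogen on an aromatic carbon), relative to compound 2. The step from compound 2 to compound 4 is expected to be a 1.3-fold higher number from compound 2 to compound 4 (0.11 log units; within the scatter), about as small as the earlier one, because the step of a 1.3-fold higher number from compound 1 to compound 3 (0.11 log units; within the scatter) stayed within the scatter. Compound 4 is therefore estimated at 6 nM, with a likely range from 3 nM to 12 nM.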

Compound 4, dissociation constant: 12.2 nM
Estimate against measurement, compound 4: 2.0-fold (0.31 log units) below; measured number above the stated range.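

In this assay, the change from phenyl to 4-chlorophenyl gives a 2.6-fold higher number from compound 2 to compound 4 (0.42 log units; beyond the scatter), a modest step that lies beyond the scatter, whereas the earlier step with the same change does not. Set side by side, the two steps cannot be told apart: the same change on two cores in this assay, a 1.3-fold higher number (0.11 log units; within the scatter) from compound 1 to compound 3 and a 2.6-fold higher number (0.42 log units; beyond the scatter) from compound 2 to compound 4, 2.1-fold (0.31 log units) apart, within the scatter of two such steps. This shows that the change carries from one core to the other without a measurable difference, but two pairs of compounds cannot show that the steps are truly equal or that the same would hold on any further core.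

The compounds shown leave open whether a fluoro or methoxy group in the same place would give a similar step. They also leave open how the change would behave with a longer chain.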